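Nitro to Trifluoromethyl on the Fused Core

The compounds below may be only part of what the source reports. "The series", "measured", "known", "first", "only" and "open" are said of these compounds alone.

Compound 1 `CC1CCN(c2nc(=O)c3cc([N+](=O)[O-])cc([N+](=O)[O-])c3s2)CC1` carries a nitro group at the position under study, yet in an ADME assay on Vero cells (Chlorocebus sabaeus) for cytotoxicity, read by MTT assay, with a stated time of 72 h (a higher number here means a weaker inhibitor, a lower number a stronger inhibitor), compound 1 stands at "not determined" (no result reported), so no number anchors it. Among the measured compounds shown here, compound 2 `CCCCNc1nc(=O)c2cc(C(F)(F)F)cc([N+](=O)[O-])c2s1` offers the only reading: in this assay compound 2 gives > 100000 nM, which is a limit of the assay and not a number. For the measured compounds named here, the only evidence is the limit of > 100000 nM in this assay, at which 1 of the 2 values shown sits. Compound 3 `CC1CCN(c2nc(=O)c3cc(C(F)(F)F)cc([N+](=O)[O-])c3s2)CC1` arises from compound 1 by trifluoromethyl in place of nitro on an aromatic carbon. Going by the values given here, with no measured step between them, no shift beyond the scatter is expected in this assay. Compound 3 is therefore estimated near 100000 nM, between 30000 nM and 300000 nM.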

Compound 3, half-maximal inhibitory concentration: > 100000 nM
Compound 3: a limit, no number (the forecaster's own chance of this, stated with the estimate: 70%); the middle value lies on the limit itself.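

In this assay compound 3 gives > 100000 nM, a limit of the assay and not a number, so no step can be read from compound 1 or compound 2 to compound 3. The compounds shown leave open whether trifluoromethyl in place of nitro, or 4-methylpiperidin-1-yl in place of butylamino, changes this read-out at all.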